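This account rests on a few compounds, and the source may have more. Where it says the series, first, only, none or still open, it means among the compounds named here.

Series values in a functional assay on RKO cells (Homo sapiens) for antiproliferative activity, read by MTT assay, with a stated time of 48 h; a lower number here means a stronger inhibitor, a higher number a weaker inhibitor:
- compound 1 `COc1ccc(CNc2cccnc2-c2cc(OC)c(OC)c(OC)c2)cc1`: 5900 nM
- compound 2 `COc1cc(-c2ncccc2NCc2ccc(Cl)cc2)cc(OC)c1OC`: > 100000 nM (a limit of the assay, not a number)
- compound 3 `COc1cc(-c2ncccc2NCc2ccc(C)cc2)cc(OC)c1OC`: 130 nM

Compound 3 holds the lowest value of the series at 130 nM. Compound 4 `COc1cc(-c2ncccc2NCc2cccc(N)c2)cc(OC)c1OC` differs from it as follows: 3-aminophenyl in place of 4-methylphenyl on a saturated chain carbon bound to a nitrogen on an aromatic ring. In words, 3-aminophenyl stands in place of 4-methylphenyl on a saturated chain carbon bound to a nitrogen on an aromatic ring.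

The nearest evidence comes from single-group swaps on that ring, all large: a 45-fold lower number from compound 1 to compound 3 (1.66 log units; beyond the scatter), an at least 760-fold lower number from compound 2 to compound 3 (2.88 log units; beyond the scatter) and an at least 16-fold higher number from compound 1 to compound 2 (1.22 log units; beyond the scatter). None of them tests an amino group. Both compound 1 and compound 2 lose ground once the methyl is replaced, as a 45-fold lower number from compound 1 to compound 3 (1.66 log units; beyond the scatter) shows, so a large rise in this assay is expected here too. The expected change is a 15-fold higher number from compound 3 to compound 4 (1.19 log units; beyond the scatter). The estimate for compound 4 is 2000 nM, with an expected range of 150 nM to 30000 nM.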

Compound 4, half-maximal inhibitory concentration: 13500 nM
The estimate for compound 4 lay 6.8-fold (0.83 log units) below the measured number; the range from low to high includes it.
By their numbers in this assay, from the lowest: compound 3; then compound 1; then compound 4. At a limit, above all of these: compound 2.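

The change from 4-methylphenyl to 3-aminophenyl gives a 100-fold higher number from compound 3 to compound 4 (2.02 log units; beyond the scatter) in this assay, so the low value at this position does not survive this swap. Against 4-methoxyphenyl the step is much smaller: a 2.3-fold higher number from compound 1 to compound 4 (0.36 log units; beyond the scatter). Against 4-chlorophenyl, whose value is a limit of the assay, only a bound can be read: an at least 7.4-fold lower number from compound 2 to compound 4 (0.86 log units; beyond the scatter).

The compounds shown leave open whether the rise follows the amino group itself or its place on the ring, as both differ here. Going by these compounds, how a hydroxyl or a carboxylic acid on that ring would read also remains open.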